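The source may hold more compounds than are shown below. What is called first, only, known or untested is meant among the compounds shown, and "the series" means these compounds.

In a functional assay on HL-60 cells (Homo sapiens) for inhibition, read by MTT assay, with a stated time of 48 h (a higher number here means a weaker inhibitor, a lower number a stronger inhibitor), compound 3 `O=C(/C=C/c1ccc(Cl)cc1)c1ccco1` gives 19000 nM. Compound 1 `COc1cccc(/C=C/C(=O)c2ccc[nH]2)c1` gives 16000 nM and compound 2 `O=C(/C=C/c1ccc(Cl)cc1)c1ccc[nH]1` gives 13000 nM, so all three values lie within the scatter of one another. Compound 4 `O=C(/C=C/c1ccccc1)c1ccco1` differs from compound 3 at a single place: hydrogen in place of chloro on an aromatic carbon. Within the data shown here, the only measured step between compounds differing in one place, a 1.5-fold higher number from compound 2 to compound 3 (0.16 log units; within the scatter), is furan-2-yl in place of 1H-pyrrol-2-yl on a carbonyl carbon, so it bears on the change only indirectly, showing that this part of the series stays within the scatter. Among the measured compounds shown here, no measured pair isolates the removal of chloro. Compound 1, which has no chloro, gives 16000 nM, and this lies within the scatter of compound 2 at 13000 nM. No change beyond the scatter is therefore expected in this assay. The expected step is a 1.1-fold higher number from compound 3 to compound 4 (0.02 log units; within the scatter). For compound 4 the estimated value is 20000 nM, with an expected range from 10000 nM to 40000 nM.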

Compound 4, half-maximal inhibitory concentration: 100000 nM
Compound 4: middle estimate off by 5.0-fold (0.70 log units), on the low side; the whole stated range lies below it.
By their numbers in this assay, from the lowest: compounds 2, 1 and 3 (each within the scatter of the next); then compound 4.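

In this assay, the chloro on this aromatic carbon, para to a group of 9 heavy atoms, turns out to count: hydrogen in its place gives a 5.3-fold higher number from compound 3 to compound 4 (0.72 log units; beyond the scatter). This is the first single-place change shown that lies beyond the scatter, and it makes compound 4 the weaker inhibitor of the pair, whereas the exchange of 1H-pyrrol-2-yl for furan-2-yl gave only a 1.5-fold higher number from compound 2 to compound 3 (0.16 log units; within the scatter), which is within it. No measurement at hand offers an explanation for this step.

The compounds shown leave open whether a bromo, a methyl or an amine on the same carbon would give a number nearer that of compound 3 or that of compound 4. They also leave open whether hydrogen in place of chloro on compound 2, which carries 1H-pyrrol-2-yl, would give a step of similar size.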